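This account rests on a few compounds, and the source may have more. Where it says the series, first, only, none or still open, it means among the compounds named here.

Measured in an ADME assay on the whole organism (plasma) for pharmacokinetics, with Rattus norvegicus as the target, with a stated time of 6 h, at a dose of 10 mg/kg by the oral route; on this read-out lower numbers stand for lower exposure and higher numbers for higher exposure at the dose given:
- compound 1 `Cc1ccc([C@@H](C)Nc2c(Nc3cccc(C(=O)N(C)C)c3O)c(=O)c2=O)o1`: 13000 ng.h/mL
- compound 2 `Cc1ccc([C@H](Nc2c(Nc3cccc(C(=O)N(C)C)c3O)c(=O)c2=O)C2CC2)o1`: 573 ng.h/mL
- compound 3 `Cc1ccc([C@H](Nc2c(Nc3cccc(C(=O)N(C)C)c3O)c(=O)c2=O)C(C)C)o1`: 1320 ng.h/mL

Compound 3, at 1320 ng.h/mL, stands second highest of the three. Compound 4 `Cc1ccc([C@H](Nc2c(Nc3cccc(C(=O)N(C)C)c3O)c(=O)c2=O)C(C)(C)C)o1` differs from it by methyl in place of hydrogen on a saturated chain carbon bound to three saturated chain carbons, which turns isopropyl into tert-butyl. Among the measured compounds shown here, no measured step makes this exact change. The nearest evidence is a 9.8-fold lower number from compound 1 to compound 3 (0.99 log units; beyond the scatter) and a 23-fold lower number from compound 1 to compound 2 (1.36 log units; beyond the scatter), both falls on leaving methyl, while a 2.3-fold higher number from compound 2 to compound 3 (0.36 log units; beyond the scatter) is much smaller. Once methyl has gone, the numbers of the two compounds lie fairly close, so only a slight fall is expected in this assay, within the scatter. The expected change is a 1.7-fold lower number from compound 3 to compound 4 (0.22 log units; within the scatter). Compound 4 is estimated at 800 ng.h/mL, with an expected range of 200 ng.h/mL to 3200 ng.h/mL.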

Compound 4, area under the concentration-time curve: 1110 ng.h/mL
Compound 4: the middle estimate sits 1.4-fold (0.14 log units) below what was measured; the range from low to high includes it.
By their numbers in this assay, from the lowest: compounds 2, 4 and 3 (each within the scatter of the next, the first and the last beyond it); then compound 1.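

In this assay, the change from isopropyl to tert-butyl gives a step within the scatter (a 1.2-fold lower number from compound 3 to compound 4 (0.08 log units; within the scatter)), as does tert-butyl in place of cyclopropyl (a 1.9-fold higher number from compound 2 to compound 4 (0.29 log units; within the scatter)). Among the compounds shown here, only the step from methyl lies beyond the scatter (a 12-fold lower number from compound 1 to compound 4 (1.07 log units; beyond the scatter)), so tert-butyl, like cyclopropyl and isopropyl, stands well apart from methyl at this position. Nothing given here accounts for this. Open, on these data alone, is whether ethyl, hydrogen or a chain carrying an amine at this position would stay with methyl or with the other three groups.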